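Methylphenyl swap from compound 3 to compound 4

The source may hold more compounds than are shown below. What is called first, only, known or untested is meant among the compounds shown, and "the series" means these compounds.

Compound 1 `COc1cccc(/C=C/C(=O)c2sc(Nc3cccc(C)c3)nc2C)c1`, compound 2 `COc1cccc(/C=C/C(=O)c2sc(Nc3ccccc3C)nc2C)c1` and compound 3 `COc1cc(/C=C/C(=O)c2sc(Nc3ccccc3C)nc2C)cc(OC)c1OC` have been tested in a functional assay on BGC-823 cells (Homo sapiens) for cytotoxicity, read by MTT assay; on this read-out higher numbers stand for weaker inhibition and lower numbers for stronger inhibition. Compound 1 reaches only the limit of > 25000 nM in this assay. Compound 2 likewise gives only the limit of > 25000 nM. Compound 3 gives 5400 nM in this assay. Compound 1 and compound 2 differ by 3-methylphenyl in place of 2-methylphenyl on a nitrogen on an aromatic ring; the step that the two limits leave unreadable from compound 2 to compound 1 has no readable size, since both values sit at the limit of > 25000 nM in this assay, at which 2 of the 3 values shown sit. Within the data shown here, how the core of compound 3 differs from the core of compound 2 is not broken down here; their values show only that compound 3 returns a number where compound 2 returns a limit.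

Compound 4 `COc1cc(/C=C/C(=O)c2sc(Nc3cccc(C)c3)nc2C)cc(OC)c1OC` remains to be measured. It differs from compound 3 by 3-methylphenyl in place of 2-methylphenyl on a nitrogen on an aromatic ring, the same change as from compound 2 to compound 1, at the same place. The earlier occurrence gives no size, so the expectation rests on compound 3 alone with its 5400 nM as the anchor. Compound 4 is expected at 6500 nM in this assay, with a range of 2500 nM to 17000 nM. The expected step of a 1.2-fold higher number from compound 3 to compound 4 (0.08 log units; within the scatter) is accordingly estimated as small, within the scatter of repeated measurements.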

Compound 4, half-maximal inhibitory concentration: 17200 nM
Beside the measured number, compound 4's estimate is 2.6-fold (0.42 log units) below it; the measured number lies above the stated range.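

In this assay, 3-methylphenyl in place of 2-methylphenyl on a nitrogen on an aromatic ring gives a 3.2-fold higher number from compound 3 to compound 4 (0.50 log units; beyond the scatter), so on this core the change brings a modest loss of inhibition. It does not show that the change carries over from one core to another, since the same change on the core of compound 2 has no readable size, both values of that pair being limits and not numbers: the limit of > 25000 nM in this assay, at which 2 of the 4 values shown sit. The series therefore holds a single readable pair for this change, which gives its size on one core only and is no rule for the series, and nothing here tells why the number rises.

The compounds shown carry only 2-methylphenyl and 3-methylphenyl on that nitrogen, so it remains open how a plain phenyl, a chlorophenyl or a phenyl bearing a carboxylic acid would read on either core. Also open, from the compounds shown here alone, is whether the step from the core of compound 3 recurs on any further core.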